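Moving the Chlorine: From Compound 2 to Compound 4

This account rests on a few compounds, and the source may have more. Where it says the series, first, only, none or still open, it means among the compounds named here.

Compound 1, `O=c1ccoc2cc(OCc3cn(Cc4ccccc4)nn3)ccc12`, in a functional assay on A549 cells (Homo sapiens) for cytotoxicity, read by MTT assay, with a stated time of 48 h (on this read-out lower numbers stand for stronger inhibition and higher numbers for weaker inhibition), gives > 100000 nM, which is a limit of the assay and not a number.
Compound 2, `O=c1ccoc2cc(OCc3cn(Cc4ccc(Cl)cc4)nn3)ccc12`, gives > 100000 nM, again only a limit.
Compound 3, `O=c1ccoc2cc(OCc3cn(Cc4cccc([N+](=O)[O-])c4)nn3)ccc12`, gives 9450 nM.

Compound 2 thus stands at the limit, one of the two values sitting there (the limit of > 100000 nM in this assay, at which 2 of the 3 values shown sit). Compound 4, `O=c1ccoc2cc(OCc3cn(Cc4ccccc4Cl)nn3)ccc12`, differs from compound 2 by 2-chlorophenyl in place of 4-chlorophenyl on a saturated chain carbon bound to an aromatic nitrogen. For the measured compounds named here, no measured step shifts the chloro from one ring position to another. The step that the two limits leave unreadable from compound 1 to compound 2 has limits at both ends and cannot be read. The step of an at least 10-fold lower number from compound 2 to compound 3 (1.02 log units; beyond the scatter) brings in a nitro group instead and so says nothing about where a chloro sits. The expected step is therefore a number no higher from compound 2 to compound 4 (the limit leaves the size open), none beyond the scatter. Compound 4 is estimated at 100000 nM, ranging from 30000 nM to 300000 nM, and a limit rather than a number is again quite possible.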

Compound 4, half-maximal inhibitory concentration: > 100000 nM
Compound 4: no number, only a limit (the forecaster's own chance of this, stated with the estimate: 60%); the middle value lies on the limit itself.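

Moving the chlorine from 4-chlorobenzyl to 2-chlorobenzyl leaves compound 4 at a limit of this assay, so neither chloro placement yields a number. The one readable step is an at least 10-fold higher number from compound 3 to compound 4 (1.02 log units; beyond the scatter), and it replaces 3-nitrophenyl with 2-chlorophenyl, so compound 3 remains the only compound shown with a number. The steps linking compound 4 to compound 1 and to compound 2 cannot be read, with a limit at both ends: the limit of > 100000 nM in this assay, at which 3 of the 4 values shown sit.

From the compounds shown here alone, whether the two chloro placements truly differ stays open. So does what an amine or a carboxylic acid on that benzyl ring would give.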